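Benzyl swap in a series held at the assay limit

The source may report more compounds than this note shows. Statements on the series, on what has been measured and on what is new or still open speak of the compounds shown alone.

In a functional assay on HOS cells (Homo sapiens) for antiproliferative activity, with a stated time of 72 h (a lower number here means a stronger inhibitor, a higher number a weaker inhibitor), so far:
- compound 1 (`Cc1cccc(CNc2ncnc3c2ncn3[C@@H]2O[C@H](CO)[C@@H](O)[C@H]2O)c1`) gives > 166000 nM as a limit
- compound 2 (`COc1ccccc1CNc1ncnc2c1ncn2[C@@H]1O[C@H](CO)[C@@H](O)[C@H]1O`) gives > 166000 nM as a limit
- compound 3 (`OC[C@H]1O[C@@H](n2cnc3c(NCc4ccc(Cl)c(Cl)c4)ncnc32)[C@H](O)[C@@H]1O`) gives > 166000 nM as a limit

Compound 3 stands at its limit of > 166000 nM and has no number. The two other values are limits as well, and all three sit at the same one (the limit of > 166000 nM in this assay, at which 3 of the 3 values shown sit).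

Compound 4 (`OC[C@H]1O[C@@H](n2cnc3c(NCc4ccc(F)cc4Cl)ncnc32)[C@H](O)[C@@H]1O`) carries 2-chloro-4-fluorophenyl in place of 3,4-dichlorophenyl on a saturated chain carbon bound to a nitrogen on an aromatic ring.

Going by the values given here, the steps that bear on this change were made at the same place (a step that the two limits leave unreadable from compound 1 to compound 3) and (a step that the two limits leave unreadable from compound 2 to compound 3), and the third one is similar (a step that the two limits leave unreadable from compound 1 to compound 2). None of them has a readable size, so none gives a direction. All three compounds remain at the limit whichever of these groups they carry.

What is expected is therefore (a number no higher from compound 3 to compound 4 (the limit leaves the size open)) with no direction and nothing beyond the scatter. In this assay the estimate for compound 4 is 166000 nM with an expected range of 60000 nM to 300000 nM and the likeliest report is again only a limit.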

Compound 4, half-maximal inhibitory concentration: > 166000 nM
Compound 4: a limit, no number (the forecaster's own chance of this, stated with the estimate: 80%); the middle value sits exactly at the limit.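

In this assay compound 4 gives > 166000 nM, a limit and not a number. Its steps to compound 1, compound 2 and compound 3 cannot be read, because all four compounds rest at the same limit: the limit of > 166000 nM in this assay, at which 4 of the 4 values shown sit. The compounds shown leave open how far beyond that limit each one lies in this assay, and whether the benzyl swap changes anything.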